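The compounds below may be only part of what the source reports. "The series", "measured", "known", "first", "only" and "open" are said of these compounds alone.

Compound 1 `Cn1nc2c(=O)n(CC3(O)CCN(Cc4ccc(-c5ccco5)cc4Cl)CC3)cnc2c1-c1ccc(CNC(=O)C(F)(F)F)cc1` gives 2060 nM in an assay on isolated protein for inhibition of ubiquitin carboxyl-terminal hydrolase 7 (Homo sapiens), with stated times of 30 min and 2 h; a lower number here means a stronger inhibitor, a higher number a weaker inhibitor.
Compound 2 `Cn1nc2c(=O)n(CC3(O)CCN(Cc4ccc(-c5cnco5)cc4Cl)CC3)cnc2c1-c1ccc(CN)cc1` gives 71.6 nM in this assay.
Compound 3 `Cn1nc2c(=O)n(CC3(O)CCN(Cc4ccc(-c5ccco5)cc4Cl)CC3)cnc2c1-c1ccc(CNS(C)(=O)=O)cc1` gives 65.3 nM in this assay.

Compound 2 stands second highest of the three numbers: its number lies within the usual scatter of that of compound 3, while compound 1 sits far higher. Compound 4 `Cn1nc2c(=O)n(CC3(O)CCN(Cc4ccc(-c5ncco5)cc4Cl)CC3)cnc2c1-c1ccc(CN)cc1` is made from compound 2 by 1,3-oxazol-2-yl in place of 1,3-oxazol-5-yl on an aromatic carbon. Among the measured compounds shown here, the one measured step, a 32-fold lower number from compound 1 to compound 3 (1.50 log units; beyond the scatter), changes a group on an amine nitrogen elsewhere in the molecule and therefore says nothing direct about moving the attachment point of the oxazole ring. Compound 2 differs from compounds 1 and 3 at more than one place, so no single step is shown for those pairs. For the measured compounds named here, with no measured step on the oxazole itself, the change is expected to leave the number near that of compound 2, and compound 4 is estimated at 80 nM, with a range from 30 nM to 220 nM. The expected step is a 1.1-fold higher number from compound 2 to compound 4 (0.05 log units; within the scatter), which is within the scatter.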

Compound 4, half-maximal inhibitory concentration: 1120 nM
Beside the measured number, compound 4's estimate is 14-fold (1.15 log units) below it; the whole stated range lies below it.
By their numbers in this assay, from the lowest: compounds 3 and 2 (each within the scatter of the next); then compounds 4 and 1 (each within the scatter of the next).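

The earlier compounds shown here held no step at the oxazole ring. Here, 1,3-oxazol-2-yl in place of 1,3-oxazol-5-yl gives a 16-fold higher number from compound 2 to compound 4 (1.19 log units; beyond the scatter) in this assay, a large change from moving only the ring's point of attachment. Both groups have the same atoms and the same counts of hydrogen-bond donors and acceptors, and both sit on the same aromatic carbon, so the step belongs to how the ring is joined, not to what it is made of. Nothing measured here explains why this change has such an effect.

Left open is whether another five-membered ring at this place, such as 1,3-thiazol-2-yl or 1,3-oxazol-4-yl, would stay close to compound 2. As far as these compounds go, the step is also seen on one background only, and how 1,3-oxazol-2-yl behaves alongside the methylsulfonyl group of compound 3 remains open.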